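The source may report more compounds than this note shows. Statements on the series, on what has been measured and on what is new or still open speak of the compounds shown alone.

Compounds measured so far:
- compound 1, `COC(=O)C1=C(C)N=C(C)/C(=C(\O)OC)C1c1cccc([N+](C)(C)C)c1`, gives 50100 nM
- compound 2, `COC(=O)C1=C(C)N=C(C)/C(=C(\O)OC)C1c1cc(Cl)cc(Cl)c1`, gives 93.3 nM
- compound 3, `COC(=O)C1=C(C)N=C(C)/C(=C(\O)OC)C1c1c(F)c(F)c(F)c(F)c1F`, gives 4.37 nM

All three were tested in a functional assay (muscle tissue) with Cavia porcellus as the target; a lower number here means that less compound is needed, a higher number that more compound is needed for the effect. Among these three numbers compound 2 stands second highest: compound 3 sits beyond the usual scatter below it, and compound 1 sits far beyond the scatter above it, so the three compounds are clearly ordered, with compound 3 needing the least material and compound 1 the most.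

The next compound, compound 4, is `COC(=O)C1=C(C)N=C(C)/C(=C(\O)OC)C1c1ccccc1Br`. It differs from compound 2 in one place: 2-bromophenyl in place of 3,5-dichlorophenyl on a saturated ring carbon. Among the measured compounds shown here, no measured pair here shows this particular exchange, so the expectation rests only on the three values above. Two of the three compounds that carry halogen on the phenyl ring give low numbers, and compound 3, with the most halogen atoms, gives the lowest, while the charged trimethylammonium of compound 1 gives by far the highest. A halogen-bearing phenyl is kept in compound 4, so a number closer to compound 2 and compound 3 than to compound 1 is expected. Compound 4 is therefore estimated at 20 nM in this assay, with a range from 4 nM to 100 nM. The expected step from compound 2 to compound 4 is a 4.7-fold lower number from compound 2 to compound 4 (0.67 log units; beyond the scatter), a modest move toward a lower number, possibly within the scatter.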

Compound 4, half-maximal effective concentration: 7.59 nM
Beside the measured number, compound 4's estimate is 2.6-fold (0.42 log units) above it, within the range that was stated.
By their numbers in this assay, from the lowest: compounds 3 and 4 (each within the scatter of the next); then compound 2; then compound 1.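

In this assay, 2-bromophenyl in place of 3,5-dichlorophenyl gives a 12-fold lower number from compound 2 to compound 4 (1.09 log units; beyond the scatter), so the number at this saturated ring carbon depends strongly on which halogen-bearing phenyl group it carries. The new result also shows that many halogen atoms are not needed for a low number in this series: compound 4 at 7.59 nM, with its single bromine, and compound 3 at 4.37 nM, with five fluorines, lie within the usual scatter of each other. Nothing available here explains why this exchange has so large an effect.

This exchange alters the kind of halogen, the number of halogen atoms and where they sit on the phenyl ring all at once, so the compounds shown cannot separate these three changes. They also leave open how a plain phenyl with no substituent would compare, and whether a methyl, a methoxy group, a nitro group or an amine in place of the bromine of 2-bromophenyl would keep the number close to that of compound 4.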